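The source may report more compounds than this note shows. Statements on the series, on what has been measured and on what is new or still open speak of the compounds shown alone.

- Compound 1 `COC(=O)c1ccc(N(Cc2ccc(C3CCCCC3)cc2)C(=O)[C@H]2CCN2S(=O)(=O)c2c(F)c(F)c(F)c(F)c2F)cc1O`: 2700 nM
- Compound 2 `COC(=O)c1ccc(N(Cc2ccc(C3CCCCC3)nc2)C(=O)[C@H]2CCN2S(=O)(=O)c2c(F)c(F)c(F)c(F)c2F)cc1O`: 2000 nM
- Compound 3 `COC(=O)c1ccc(N(Cc2cnc(C3CCCCC3)cn2)C(=O)[C@H]2CCN2S(=O)(=O)c2c(F)c(F)c(F)c(F)c2F)cc1O`: 1600 nM

These values come from a functional assay on MDA-MB-231 cells (Homo sapiens) for antiproliferative activity, with a stated time of 72 h; a higher number here means that more compound is needed for the effect, a lower number that less compound is needed. Compound 1 cannot be told apart from the other two: a 1.4-fold lower number from compound 1 to compound 2 (0.13 log units; within the scatter) and a 1.7-fold lower number from compound 1 to compound 3 (0.23 log units; within the scatter), both within the usual scatter. The remaining pair behaves alike, with a 1.3-fold lower number from compound 2 to compound 3 (0.10 log units; within the scatter), also within the scatter. All three steps concern the group on a saturated chain carbon bound to an amide-type nitrogen, where 4-cyclohexylphenyl, 6-cyclohexylpyridin-3-yl and 5-cyclohexylpyrazin-2-yl are exchanged.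

Compound 4 `O=C([C@H]1CCN1S(=O)(=O)c1c(F)c(F)c(F)c(F)c1F)N(Cc1ccc(C2CCCCC2)cc1)c1ccc2c(=O)[nH]ccc2c1` keeps the 4-cyclohexylphenyl group of compound 1 but changes a different place, on the amide-type nitrogen: a group of 11 heavy atoms (9 carbon, 1 nitrogen, 1 oxygen; one six-membered aromatic ring of carbon only, one six-membered aromatic ring with 1 hetero atom) in place of a group of 11 heavy atoms (8 carbon, 3 oxygen; one six-membered aromatic ring of carbon only), on an amide-type nitrogen. For the measured compounds named here, none of the measured steps touches this place, so they give no direct guide to its effect on this assay. With no evidence for a direction, the expectation stays anchored on compound 1 at 2700 nM, and no step beyond the scatter is expected, though with real uncertainty. The estimated step is a 1.1-fold higher number from compound 1 to compound 4 (0.05 log units; within the scatter). For compound 4 the estimated value is 3000 nM, with an expected range from 900 nM to 10000 nM.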

Compound 4, half-maximal effective concentration: 1400 nM
For compound 4 the middle estimate is 2.1-fold (0.33 log units) above the measured one; low and high end bracket the measured number.
By their numbers in this assay, from the lowest: compounds 4, 3, 2 and 1 (each within the scatter of the next).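

In this assay, the change on the amide-type nitrogen gives a 1.9-fold lower number from compound 1 to compound 4 (0.29 log units; within the scatter), so compound 4 cannot be told apart from compound 1 even though 3-hydroxy-4-(methoxycarbonyl)phenyl has been replaced. This shows that, with the 4-cyclohexylphenyl group held constant, this position accepts a group with a second six-membered aromatic ring carrying 1 hetero atom, without a step beyond the scatter. The hydrogen-bond acceptors of the group fall from 3 to 1 while its single hydrogen-bond donor count stays the same, but no measurement here accounts for the outcome.

As far as these compounds go, what a carboxylic acid in place of the methoxycarbonyl group, or a plain phenyl ring carrying neither the hydroxy nor the methoxycarbonyl group, would do at this position remains open. Also open is whether the group of compound 4 would give a similar number when paired with 6-cyclohexylpyridin-3-yl or 5-cyclohexylpyrazin-2-yl on the saturated chain carbon, since the compounds shown do not test the two places together.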